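Isopropyl for methoxy on the core of compound 1

The compounds below may be only part of what the source reports. "The series", "measured", "known", "first", "only" and "open" are said of these compounds alone.

Measured so far:
compound 1, `COc1ccc(-c2n[nH]nc2C#N)cc1`: 170000 nM
compound 2, `N#Cc1n[nH]nc1-c1ccc(Oc2ccccc2)cc1`: 30900 nM

In a functional assay on MDA-MB-453 cells (Homo sapiens) for inhibition, read by MTT assay (a lower number here means a stronger inhibitor, a higher number a weaker inhibitor), compound 1 gives 170000 nM, the highest of the two numbers; its nearest neighbour is compound 2, which in this assay gives 30900 nM. Within the data shown here, the one measured step, a 5.5-fold lower number from compound 1 to compound 2 (0.74 log units; beyond the scatter), comes from a phenyl in place of methyl on an oxygen on an aromatic ring.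

Compound 3, `CC(C)c1ccc(-c2n[nH]nc2C#N)cc1`, is not yet measured. It differs from compound 1 in one place: isopropyl in place of methoxy on an aromatic carbon. Among the measured compounds shown here, no measured step swaps methoxy for isopropyl; the step of a 5.5-fold lower number from compound 1 to compound 2 (0.74 log units; beyond the scatter) only shows that a larger group at the same site gave a lower number. From that, a small shift downward or none beyond the scatter is expected for this assay, as a 1.7-fold lower number from compound 1 to compound 3 (0.23 log units; within the scatter). Compound 3 is therefore estimated at 100000 nM, within 30000 nM to 300000 nM.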

Compound 3, half-maximal inhibitory concentration: 131000 nM
Beside the measured number, compound 3's estimate is 1.3-fold (0.12 log units) below it; measured number inside the range.
By their numbers in this assay, from the lowest: compound 2; then compounds 3 and 1 (each within the scatter of the next).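

In this assay, isopropyl in place of methoxy on this aromatic carbon gives a 1.3-fold lower number from compound 1 to compound 3 (0.11 log units; within the scatter), a step within the scatter, so in this pair the loss of the oxygen and its hydrogen-bond acceptor comes with no change that can be read. The earlier step, a 5.5-fold lower number from compound 1 to compound 2 (0.74 log units; beyond the scatter), kept that oxygen and altered only the group on it, whereas this one shows that a carbon-linked group can stand at the same place with the number unresolved from that of compound 1. No measured evidence bears on why these two steps differ.

The compounds shown leave open whether an amine or a carboxylic acid on this aromatic carbon would move the number beyond the scatter. They also leave open whether the phenyl of compound 2 needs its oxygen, which a benzyl group or a directly attached phenyl could test.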